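This account rests on a few compounds, and the source may have more. Where it says the series, first, only, none or still open, it means among the compounds named here.

Measured compounds:
compound 1, `COc1cc(C2CC(c3ccccc3)=NN2C(=O)OCc2ccccc2)cc(OC)c1OC`: > 10000 nM
compound 2, `COc1ccc(C2=NN(C(=O)OCc3ccccc3)C(c3cc(OC)c(OC)c(OC)c3)C2)cc1`: > 10000 nM
compound 3, `COC(=O)N1N=C(c2ccccc2)CC1c1ccc(OC)c(OC)c1`: 7320 nM

In a functional assay on A549 cells (Homo sapiens) for antiproliferative activity, read by MTT assay, with a stated time of 48 h (on this read-out lower numbers stand for stronger inhibition of growth and higher numbers for weaker inhibition of growth), compound 1 reaches only a limit of the assay, > 10000 nM. Compound 2 likewise gives only a limit, > 10000 nM. Within the data shown here, compound 3 is the one compound with a number in this assay, 7320 nM.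

The change from compound 1 to compound 2 is methoxy in place of hydrogen on an aromatic carbon; the step that the two limits leave unreadable from compound 1 to compound 2 cannot be sized because of the limit of > 10000 nM in this assay, at which 2 of the 3 values shown sit. Compound 4, `COC(=O)N1N=C(c2ccccc2)CC1c1cc(OC)c(OC)cc1OC`, is not yet measured and differs from compound 3 by methoxy in place of hydrogen on an aromatic carbon. Among the measured compounds shown here, this is the same kind of change as the one from compound 1 to compound 2, but the place is not the same: in compound 2 the entering methoxy is para to a large group, whereas in compound 4 it is ortho to a large group, meta to a methoxy group and para to a methoxy group. The difference between the cores of compound 1 and compound 3 is not broken down here.

For the measured compounds named here, with the one measured step unreadable, no size can be carried over, and the expectation rests only on the value of compound 3, 7320 nM. The step of a 1.0-fold lower number from compound 3 to compound 4 (0.02 log units; within the scatter) is expected to be small. Compound 4 is expected to give 7000 nM in this assay, between 2500 nM and 20000 nM.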

Compound 4, concentration for 50% growth inhibition: 5320 nM
For compound 4 the middle estimate is 1.3-fold (0.12 log units) above the measured one, and the stated range covers the measured number.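

In this assay, methoxy in place of hydrogen on an aromatic carbon of the core of compound 3, ortho to a large group, meta to a methoxy group and para to a methoxy group, gives a 1.4-fold lower number from compound 3 to compound 4 (0.14 log units; within the scatter), so on this core and at this place the change leaves the read-out within the usual scatter. The step for the same kind of change on the other core, from compound 1 to compound 2, cannot be read, and no comparison between the two cores is possible because both of its values are limits: the limit of > 10000 nM in this assay, at which 2 of the 4 values shown sit. The series therefore shows one readable instance of the change, at a place that is not the same as in compound 2, and it does not show whether the result carries from one core to the other.

As far as these compounds go, the separate contribution of each difference between the core of compound 1 and the core of compound 3 remains open. Also open, from the compounds shown here alone, is how this assay would respond to an amine or a carboxylic acid at the place taken by the entering methoxy in compound 4.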